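Sulfonamide replacement of the anilide in the benzimidazole chalcone series

The compounds below may be only part of what the source reports. "The series", "measured", "known", "first", "only" and "open" are said of these compounds alone.

Compound 3 `Cc1cc(C)cc(C(=O)Nc2cccc(/C=C/C(=O)c3nc4ccccc4[nH]3)c2)c1` gives 4020 nM in a functional assay on 143B cells (Homo sapiens) for antiproliferative activity, read by MTT assay, with a stated time of 48 h (a higher number here means a weaker inhibitor, a lower number a stronger inhibitor), and sits at the low end of the three values. Compound 1 `O=C(Nc1cccc(/C=C/C(=O)c2nc3ccccc3[nH]2)c1)c1cccc(Br)c1` gives 4620 nM, and a 1.1-fold lower number from compound 1 to compound 3 (0.06 log units; within the scatter). Compound 2 `Cc1ccccc1C(=O)Nc1cccc(/C=C/C(=O)c2nc3ccccc3[nH]2)c1` gives 8290 nM, and a 2.1-fold lower number from compound 2 to compound 3 (0.31 log units; beyond the scatter). Compound 4 `O=C(/C=C/c1cccc(NS(=O)(=O)c2ccc(Cl)cc2)c1)c1nc2ccccc2[nH]1` differs from compound 3 in that ((4-chlorophenyl)sulfonyl in place of (3,5-dimethylphenyl)carbonyl on a nitrogen on an aromatic ring). Among the compounds with values here, the measured steps of a 1.8-fold higher number from compound 1 to compound 2 (0.25 log units; within the scatter) and a 1.1-fold lower number from compound 1 to compound 3 (0.06 log units; within the scatter) only vary the aryl substituent on a retained carbonyl and are small; no measured step exchanges carbonyl for sulfonyl, so they bear weakly on this change. The expected step of a 1.2-fold higher number from compound 3 to compound 4 (0.09 log units; within the scatter) is therefore none beyond the scatter, with wide uncertainty. Compound 4 is estimated at 5000 nM, range 1500 nM to 17000 nM.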

Compound 4, half-maximal inhibitory concentration: 7450 nM
The estimate for compound 4 lay 1.5-fold (0.17 log units) below the measured number; the range from low to high includes it.
By their numbers in this assay, from the lowest: compounds 3, 1, 4 and 2 (each within the scatter of the next, the first and the last beyond it).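

Exchanging the carbonyl on the nitrogen for a sulfonyl, with (4-chlorophenyl)sulfonyl as the entering group, leaves the number within the scatter against each anilide: (a 1.9-fold higher number from compound 3 to compound 4 (0.27 log units; within the scatter)), (a 1.1-fold lower number from compound 2 to compound 4 (0.05 log units; within the scatter)) and (a 1.6-fold higher number from compound 1 to compound 4 (0.21 log units; within the scatter)). This position therefore accepts a sulfonamide as well as an amide in these four compounds, with no step beyond the scatter. No measured evidence accounts for these numbers.

Each step changes both the linking group and the aryl group, so their contributions cannot be separated; a (3,5-dimethylphenyl)sulfonyl group would do this. On these data alone, a methylsulfonyl group on this nitrogen, with no aromatic ring, remains open.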